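The source may report more compounds than this note shows. Statements on the series, on what has been measured and on what is new or still open speak of the compounds shown alone.

Measured so far in a physicochemical assay for lipophilicity, using the shake flask method, in phosphate buffer, measured as octanol-water partition, with a stated time of 30 min, at pH 7.4; on this read-out lower numbers stand for lower lipophilicity and higher numbers for higher lipophilicity:
- compound 1 `CN(c1ccn(C)n1)c1cnc(NCc2c(F)ccc3c2CCO3)c2cn[nH]c(=O)c12`: 2.4
- compound 2 `CN(C)C(=O)c1cc(-c2cnc(NCc3c(F)ccc4c3CCO4)c3cn[nH]c(=O)c23)n(C)n1`: 2.1
- compound 3 `Cn1nccc1-c1cnc(NCc2c(F)ccc3c2CCO3)c2cn[nH]c(=O)c12`: 2.6

Compound 3 holds the highest of the three numbers in this assay. The gap to compound 1 is small: a number 0.20 log units higher from compound 1 to compound 3 (within the scatter). The gap to compound 2 is larger and counts: a number 0.50 log units higher from compound 2 to compound 3 (beyond the scatter). The third step, a number 0.30 log units lower from compound 1 to compound 2 (within the scatter), stays within the usual scatter.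

Compound 4 `Cc1ncc(-c2cnc(NCc3c(F)ccc4c3CCO4)c3cn[nH]c(=O)c23)n1C` has not yet been measured in this assay. The change from compound 3 is 1,2-dimethyl-1H-imidazol-5-yl in place of 1-methyl-1H-pyrazol-5-yl on an aromatic carbon. For the measured compounds named here, no measured step swaps one five-membered aromatic ring for another of the same kind. The two steps leaving compound 1 exchange the methyl(1-methyl-1H-pyrazol-3-yl)amino group for a whole ring and stay within the scatter or barely move; only a number 0.50 log units higher from compound 2 to compound 3 (beyond the scatter), which removes a dimethylcarbamoyl, is a clear step. The present change adds one carbon and keeps the count of donors and acceptors, so no step beyond the scatter is expected in this assay, with at most a slight downward drift.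

Compound 4 is therefore estimated at 2.4 in this assay, between 2 and 2.8. This estimate corresponds to an expected step of a number 0.20 log units lower from compound 3 to compound 4 (within the scatter).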

Compound 4, distribution coefficient: 1.9
For compound 4 the middle estimate is 0.50 log units above the measured one, and the stated range ends above it.
By their numbers in this assay, from the lowest: compounds 4, 2, 1 and 3 (each within the scatter of the next, the first and the last beyond it).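

In this assay, exchanging one five-membered aromatic ring for another on this aromatic carbon is a clear change: a number 0.70 log units lower from compound 3 to compound 4 (beyond the scatter), although the entering 1,2-dimethyl-1H-imidazol-5-yl has the same counts of donors and acceptors as the leaving 1-methyl-1H-pyrazol-5-yl. Those counts therefore do not settle the number at this position, and the same replacement gives a number 0.50 log units lower from compound 1 to compound 4 (beyond the scatter), while a number 0.20 log units lower from compound 2 to compound 4 (within the scatter) places a ring without dimethylcarbamoyl within the scatter of the compound that bears that group. Nothing available accounts for the size of the step from the pyrazole to the imidazole.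

The change alters the ring and adds a methyl at once, so the compounds shown cannot separate the two; a 1-methyl-1H-imidazol-5-yl at the same place would make that comparison. From the compounds shown here alone, how a dimethylcarbamoyl or a primary amine on the 1,2-dimethyl-1H-imidazol-5-yl would read in this assay also stays open, and with it whether the step seen for dimethylcarbamoyl on the pyrazole carries over to the imidazole.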